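Methoxy on the benzyl ring: the next step

The compounds below may be only part of what the source reports. "The series", "measured", "known", "first", "only" and "open" are said of these compounds alone.

Compound 3 `COC(=O)N1[C@@H]2C=C[C@@](OC)(C(=O)c3c2cc(OC)c(OC)c3OCc2ccccc2)N1C(=O)OC` carries a benzyloxy group on the shared core. In an ADME assay on KB cells (Homo sapiens) for cytotoxicity (on this read-out higher numbers stand for an effect only at larger amounts of compound and lower numbers for an effect already at smaller amounts), compound 3 reaches only a limit of the assay, > 300 ug/mL. Compound 1 `CCCCOc1c(OC)c(OC)cc2c1C(=O)[C@]1(OC)C=C[C@H]2N(C(=O)OC)N1C(=O)OC`, with a butoxy chain in the same position, also sits at that limit, giving > 300 ug/mL in this assay. Compound 2 `COC(=O)N1[C@@H]2C=C[C@@](OC)(C(=O)c3c2cc(OC)c(OC)c3OCc2ccc(F)cc2)N1C(=O)OC` differs from compound 3 by a single fluoro. In this assay compound 2 gives 56.6 ug/mL. The related steps are an at least 5.3-fold lower number from compound 1 to compound 2 (0.72 log units; beyond the scatter) and an at least 5.3-fold higher number from compound 2 to compound 3 (0.72 log units; beyond the scatter); the step that the two limits leave unreadable from compound 1 to compound 3 cannot be sized, since both ends rest on (the limit of > 300 ug/mL in this assay, at which 2 of the 3 values shown sit).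

Compound 4 `COC(=O)N1[C@@H]2C=C[C@@](OC)(C(=O)c3c2cc(OC)c(OC)c3OCc2ccc(OC)cc2)N1C(=O)OC` is the next compound: methoxy in place of hydrogen on an aromatic carbon. The step from compound 2 to compound 3 shows that replacing a small substituent on that aromatic carbon with hydrogen raised the number at least modestly; the reverse move, putting a substituent back in, may therefore lower it. Whether methoxy behaves like fluoro is not settled by these three compounds, and a number at the limit remains quite possible.

The expected result for compound 4 in this assay is 130 ug/mL, within 35 ug/mL to 300 ug/mL, which would be a step of an at least 2.3-fold lower number from compound 3 to compound 4 (0.36 log units; beyond the scatter).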

Compound 4, concentration for half-maximal effect: > 300 ug/mL
Compound 4 was reported as a limit; the forecaster's own chance of this, stated with the estimate: 45%; at least 2.3-fold (0.36 log units) between middle value and limit.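

Methoxy in place of fluoro gives an at least 5.3-fold higher number from compound 2 to compound 4 (0.72 log units; beyond the scatter) in this assay. Putting a group on this aromatic carbon is therefore not enough on its own to lower the number: of the three groups shown there, hydrogen, fluoro and methoxy, only fluoro gives a value short of the limit. The steps to compound 4 from compound 3 and from compound 1 cannot be read, because both ends of each rest on a limit: the limit of > 300 ug/mL in this assay, at which 3 of the 4 values shown sit.

On these data alone, whether methoxy differs from hydrogen at all stays open, since the true number for each of these two compounds lies beyond what the limit reveals. As far as these compounds go, it is also open whether chloro or methyl on the same carbon would follow fluoro or methoxy, so the result for fluoro remains a single case.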